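The source may report more compounds than this note shows. Statements on the series, on what has been measured and on what is new or still open speak of the compounds shown alone.

Values in a physicochemical assay for lipophilicity, read by HPLC, at pH 7.5 (on this read-out lower numbers stand for lower lipophilicity and higher numbers for higher lipophilicity), for the measured compounds:
- compound 1 `CC[C@@H](Nc1c(C#N)c(-c2ccc(-c3cccc(C)c3)cc2)nc2cnccc12)C(N)=O` gives 3
- compound 2 `CC[C@@H](Nc1c(C#N)c(-c2ccc(-c3ccc(OC)cc3)cc2)nc2cnccc12)C(N)=O` gives 2.7
- compound 3 `CC[C@@H](Nc1c(C#N)c(-c2ccc(-c3ccccc3COC)cc2)nc2cnccc12)C(N)=O` gives 2.6

Compound 3 sits at the low end of these numbers. The measured steps show a number 0.40 log units lower from compound 1 to compound 3 (beyond the scatter) and a number 0.10 log units lower from compound 2 to compound 3 (within the scatter), so it is set apart only from compound 1.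

The next compound, compound 4 `CC[C@@H](Nc1c(C#N)c(-c2ccc(-c3ccc(Cl)cc3)cc2)nc2cnccc12)C(N)=O`, differs from compound 3 in one group: 4-chlorophenyl in place of 2-(methoxymethyl)phenyl on an aromatic carbon. Here 4-chlorophenyl takes the place of 2-(methoxymethyl)phenyl. Within the data shown here, no compound with 4-chlorophenyl has been measured, so any guide is indirect. The nearest evidence is compound 1, where a number 0.40 log units lower from compound 1 to compound 3 (beyond the scatter) records the arrival of the same leaving group, and a number 0.30 log units lower from compound 1 to compound 2 (within the scatter) shows that another swap at this place stayed small. Assuming that 4-chlorophenyl resembles 3-methylphenyl here, that modest step should roughly reverse. In this assay the expected change is a number 0.40 log units higher from compound 3 to compound 4 (beyond the scatter). Compound 4 is estimated at 3, with an expected range from 2.6 to 3.4.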

Compound 4, distribution coefficient: 3.1
Compound 4: the middle estimate sits 0.10 log units below what was measured; the range from low to high includes it.
By their numbers in this assay, from the lowest: compounds 3, 2, 1 and 4 (each within the scatter of the next, the first and the last beyond it).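

Swapping only the end group shows that this position can move the number in this assay by more than the scatter: with chloro in place of methoxy, the step is a number 0.40 log units higher from compound 2 to compound 4 (beyond the scatter). The full change from 2-(methoxymethyl)phenyl to 4-chlorophenyl spans the whole spread of the four compounds (a number 0.50 log units higher from compound 3 to compound 4 (beyond the scatter)), while the step from 3-methylphenyl (a number 0.10 log units higher from compound 1 to compound 4 (within the scatter)) leaves those two groups indistinguishable on this read-out. Nothing available explains why these steps take the sizes they do.

Going by these compounds, it remains open whether the chloro gives the same number when placed elsewhere on that outer ring, since every comparison here changes the group as a whole or keeps it in one spot. On these data alone, how an amine or a carboxylic acid on that ring would shift the number also remains open.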